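The source may report more compounds than this note shows. Statements on the series, on what has been measured and on what is new or still open speak of the compounds shown alone.

Compound 1, `O=C(CSc1nnc(-c2ccncc2)n1-c1ccccc1)N/N=C/c1ccc(F)cc1`, gives 9330 nM in a functional assay on HepG2 cells (Homo sapiens) for inhibition, read by MTT assay, with a stated time of 48 h; a lower number here means a stronger inhibitor, a higher number a weaker inhibitor.
Compound 2, `O=C(CSc1nnc(-c2ccncc2)n1-c1ccccc1)N/N=C/c1ccccc1F`, gives 15200 nM in this assay.
Compound 3, `O=C(CSc1nnc(-c2ccncc2)n1-c1ccccc1)N/N=C/c1ccccc1O`, gives 11300 nM in this assay.

Among these three, compound 3 has the second highest number. Its nearest neighbour is compound 1: a 1.2-fold higher number from compound 1 to compound 3 (0.08 log units; within the scatter). Its furthest is compound 2: a 1.3-fold lower number from compound 2 to compound 3 (0.13 log units; within the scatter). All three compounds share the same core and differ only in the aryl group on the carbon with a double bond to nitrogen, and none of the steps between them rises above the scatter, including a 1.6-fold higher number from compound 1 to compound 2 (0.21 log units; within the scatter).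

Compound 4, `O=C(CSc1nnc(-c2ccncc2)n1-c1ccccc1)N/N=C/C=C/c1ccccc1`, is the next compound to be tested in this assay. It differs from compound 3 in one place: 2-phenylethenyl in place of 2-hydroxyphenyl on a carbon with a double bond to nitrogen. Each of the three measured steps also swapped the group at this same position, and each stayed within the scatter. Going by the values given here, the change to compound 4 is somewhat larger than those, since the 2-phenylethenyl group adds a double bond outside aromatic rings and carries neither a hydrogen-bond donor nor an acceptor, but nothing measured so far points to a step in either direction beyond the scatter. The step expected in this assay is a 1.1-fold lower number from compound 3 to compound 4 (0.05 log units; within the scatter). Compound 4 is therefore estimated at about 10000 nM, with a range from 4000 nM to 25000 nM.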

Compound 4, half-maximal inhibitory concentration: 8280 nM
The estimate for compound 4 lay 1.2-fold (0.08 log units) above the measured number; the measured number falls inside the stated range.
By their numbers in this assay, from the lowest: compounds 4, 1, 3 and 2 (each within the scatter of the next).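

In this assay, the position on the carbon with a double bond to nitrogen also accepts 2-phenylethenyl, which brings a double bond outside aromatic rings, with a 1.4-fold lower number from compound 3 to compound 4 (0.14 log units; within the scatter), a 1.8-fold lower number from compound 2 to compound 4 (0.26 log units; within the scatter) and a 1.1-fold lower number from compound 1 to compound 4 (0.05 log units; within the scatter) all staying within the scatter. Swapping 2-hydroxyphenyl, which has a hydrogen-bond donor and acceptor, for a group with neither therefore produces no step that can be told apart from repeat-to-repeat variation, and the same holds for the swaps from 2-fluorophenyl and 4-fluorophenyl. The four groups tried here give no order at this position, and nothing available explains why their numbers lie so close together.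

On these data alone, all four groups contain a six-membered aromatic ring of carbon only, so it remains open whether an amine, a carboxylic acid or a longer saturated carbon chain at this position would produce a step beyond the scatter. Every compound shown keeps the shared core unchanged, so the effect of changes elsewhere in the molecule also remains unknown.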